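The source may report more compounds than this note shows. Statements on the series, on what has been measured and on what is new or still open speak of the compounds shown alone.

Within the data shown here, compound 3 `CNC(=O)c1ccccc1Oc1nc(Nc2ccc(C)cc2C)ncc1Br` is the one member of this small set that returns a number in a functional assay on HL-60 cells (Homo sapiens) for antiproliferative activity, read by MTT assay, with a stated time of 24 h; a lower number here means a stronger inhibitor, a higher number a weaker inhibitor: compound 3 gives 32300 nM. Compound 1 `CNC(=O)c1ccccc1Oc1nc(Nc2ccccc2F)ncc1Br` reaches only a limit of the assay, > 50000 nM. Compound 2 `CNC(=O)c1ccccc1Oc1nc(Nc2ccccc2OC)ncc1Br` likewise stops at a limit, > 50000 nM; this is the limit of > 50000 nM in this assay, at which 2 of the 3 values shown sit. The two steps that end at compound 3 therefore read as floors: an at least 1.5-fold lower number from compound 1 to compound 3 (0.18 log units; that floor lies within the scatter) and an at least 1.5-fold lower number from compound 2 to compound 3 (0.18 log units; that floor lies within the scatter), each a replacement of a 2-substituted phenyl by the 2,4-dimethylphenyl on the nitrogen on the aromatic ring. The step between the two limits stays unreadable, a step that the two limits leave unreadable from compound 1 to compound 2.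

Compound 4 `CNC(=O)c1ccccc1Oc1nc(Nc2cccc(OC)c2)ncc1Br` turns that direction around: 3-methoxyphenyl in place of 2,4-dimethylphenyl on a nitrogen on an aromatic ring. Among the measured compounds shown here, no measured step covers the 3-methoxyphenyl itself, and the two steps that bear on the change both run toward the dimethyl group and only as floors. The account therefore expects the move from a dimethylated phenyl to a methoxylated one to give back what compound 3 gained, and compound 4 is expected to drift toward the limit, a step of a 1.7-fold higher number from compound 3 to compound 4 (0.23 log units; within the scatter). The estimate for compound 4 in this assay is 55000 nM, with a range from 20000 nM to 200000 nM, and more likely than not the assay will report only a limit.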

Compound 4, half-maximal inhibitory concentration: 16200 nM
Compound 4: the middle estimate sits 3.4-fold (0.53 log units) above what was measured; measured number outside the range, below it.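

The place on the nitrogen on the aromatic ring now holds two groups that return a number in this assay, the 2,4-dimethylphenyl and the 3-methoxyphenyl, and the step between them is a 2.0-fold lower number from compound 3 to compound 4 (0.30 log units; within the scatter), so the two cannot be ordered. A methoxy group does not by itself hold a compound at the limit, since the change from the 2-methoxyphenyl to the 3-methoxyphenyl gives an at least 3.0-fold lower number from compound 2 to compound 4 (0.48 log units; beyond the scatter), and the change from the 2-fluorophenyl to the same group gives an at least 3.0-fold lower number from compound 1 to compound 4 (0.48 log units; beyond the scatter), whereas the steps into compound 3 stayed within the scatter. Both new steps are floors and not full sizes, since compound 1 and compound 2 each reach only a limit of the assay: the limit of > 50000 nM in this assay, at which 2 of the 4 values shown sit.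

Every compound shown carries the same core, so these values speak only to the aryl group on that nitrogen and say nothing about any other part of the structure. On these data alone, it remains open whether a longer chain such as an ethoxy group in place of the methoxy, or an amine or a carboxylic acid on that phenyl ring, would return a number in this assay or fall back to the limit.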